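A few compounds are considered here, and "the series" means these few. Any claim that something is new, unique, unknown or untested is made for them only; others in the source may bear on it.

Measured in a functional assay on KB cells (Homo sapiens) for antiproliferative activity, read by MTT assay, with a stated time of 48 h; a higher number here means a weaker inhibitor, a lower number a stronger inhibitor:
- Compound 1 `Cn1cc(C2=C(c3nn(CCCn4cncn4)c4ncccc34)C(=O)NC2=O)c2ccccc21`: > 100000 nM
- Compound 2 `Cn1cc(C2=C(c3nn(CCCn4cncn4)c4ncccc34)C(=O)N(c3ccccc3)C2=O)c2ccccc21`: > 100000 nM
- Compound 3 `Cn1cc(C2=C(c3nn(CCn4ccnc4)c4ncccc34)C(=O)N(c3ccccc3)C2=O)c2ccccc21`: > 100000 nM

All three entries are limits, not numbers: the limit of > 100000 nM in this assay, at which 3 of the 3 values shown sit. Compound 1 thus has no exact place on the scale, only its limit of > 100000 nM.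

Compound 4 `Cn1cc(C2=C(c3nn(CCCn4cccc4)c4ncccc34)C(=O)NC2=O)c2ccccc21` differs from compound 1 in one group: 1H-pyrrol-1-yl in place of 1H-1,2,4-triazol-1-yl on a saturated chain carbon, three bonds along the chain from an aromatic nitrogen. Here 1H-pyrrol-1-yl takes the place of 1H-1,2,4-triazol-1-yl.

Among the measured compounds shown here, two measured steps bear on this. The closer one, a step that the two limits leave unreadable from compound 2 to compound 3, also changes the ring on the chain, while a step that the two limits leave unreadable from compound 1 to compound 2 changes the amide nitrogen. Neither size can be read, so they give no direction, and no clear step is expected in this assay.

The expected step is an at least 1.2-fold lower number from compound 1 to compound 4 (0.09 log units; that floor lies within the scatter).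

The estimate for compound 4 is 80000 nM, with an expected range from 15000 nM to 200000 nM.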

Compound 4, half-maximal inhibitory concentration: > 100000 nM
Compound 4: no number, only a limit; the forecaster's own chance of this, stated with the estimate: 65%; middle value at least 1.2-fold (0.09 log units) away from the limit.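

Compound 1 and compound 4 both give only a limit in this assay, so no step between them can be read: the limit of > 100000 nM in this assay, at which 4 of the 4 values shown sit.

The compounds shown leave open whether 1H-pyrrol-1-yl in place of 1H-1,2,4-triazol-1-yl changes activity at all.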